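Amide in Place of Sulfonamide on an Indane Imidazole Core

The source may hold more compounds than are shown below. What is called first, only, known or untested is meant among the compounds shown, and "the series" means these compounds.

Compound 1 `Cn1nccc1-c1cccc2c1CCC2c1ncc[nH]1`: 278 nM
Compound 2 `CS(=O)(=O)Nc1cccc2c1CCC2c1ncc[nH]1`: 70 nM

Of the compounds shown here, two have been measured in a functional assay on CHO cells for agonist activity at Alpha-1A adrenergic receptor (Homo sapiens), read by FLIPR and calcium flux; a higher number here means that more compound is needed for the effect, a lower number that less compound is needed. Compound 1 gives 278 nM in this assay. Compound 2 gives 70 nM in this assay and stands as the lower of the two numbers, with the step of a 4.0-fold lower number from compound 1 to compound 2 (0.60 log units; beyond the scatter) separating it from compound 1.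

Compound 3 `CNC(=O)c1cccc2c1CCC2c1ncc[nH]1` has not yet been measured. Its change from compound 2 is methylcarbamoyl in place of methanesulfonamido on an aromatic carbon. Going by the values given here, the only measured step, the one from compound 1 to compound 2, concerns a different replacement at the same aromatic carbon and shows that a change there can move the number modestly. Among the compounds with values here, no step compares a methanesulfonamido group with a methylcarbamoyl group, so the direction is uncertain; both groups keep a single hydrogen-bond donor, and the sulfonamide loses one acceptor.

Compound 3 is therefore expected to land near compound 2, with a step of a 2.1-fold higher number from compound 2 to compound 3 (0.33 log units; beyond the scatter) in this assay, most likely toward a somewhat higher number. The estimated value for compound 3 is 150 nM, with a range from 50 nM to 450 nM.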

Compound 3, half-maximal effective concentration: 2200 nM
Estimate against measurement, compound 3: 15-fold (1.17 log units) below, and the stated range ends below it.
By their numbers in this assay, from the lowest: compound 2; then compound 1; then compound 3.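

In this assay, the exchange of methanesulfonamido for methylcarbamoyl at this aromatic carbon proves far from neutral: the change gives a 31-fold higher number from compound 2 to compound 3 (1.50 log units; beyond the scatter), a large step, even though both groups carry 1 hydrogen-bond donor and the entering group has 1 hydrogen-bond acceptor where the leaving group has 2. Methylcarbamoyl also compares poorly with 1-methyl-1H-pyrazol-5-yl, with a 7.9-fold higher number from compound 1 to compound 3 (0.90 log units; beyond the scatter), so among these three groups at this carbon methanesulfonamido needs the least compound for the effect and methylcarbamoyl the most, a much wider spread than the earlier step alone revealed. Nothing in the data available here accounts for the size of this change.

Going by these compounds, what stays open is whether the low number of compound 2 goes with the sulfonyl part of its group or with the nitrogen joined directly to the aromatic carbon; an acetamido group, which keeps that nitrogen but has a carbonyl in place of the sulfonyl, would separate the two. The compounds shown also leave open how a plain amine or a carboxylic acid would behave at this same carbon.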